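From 2-fluorophenyl to pyridin-3-yl on a shared core

The source may report more compounds than this note shows. Statements on the series, on what has been measured and on what is new or still open speak of the compounds shown alone.

In a functional assay on MCF7 cells (Homo sapiens) for antiproliferative activity, read by MTT assay, with a stated time of 48 h (on this read-out higher numbers stand for weaker inhibition and lower numbers for stronger inhibition), compound 1 (`CC(=O)N1N=C(c2ccc3ccccc3c2)OC1c1ccccc1Cl`) gives 2.36 ug/mL, compound 2 (`CC(=O)N1N=C(c2ccc3ccccc3c2)OC1c1ccccc1F`) gives 3.44 ug/mL and compound 3 (`CC(=O)N1N=C(c2ccc3ccccc3c2)OC1c1ccccn1`) gives 6.02 ug/mL. Compound 2 lies within the scatter of both others, with a 1.5-fold higher number from compound 1 to compound 2 (0.16 log units; within the scatter). Compound 4 (`CC(=O)N1N=C(c2ccc3ccccc3c2)OC1c1cccnc1`) has pyridin-3-yl in place of 2-fluorophenyl on a saturated ring carbon. Going by the values given here, no measured compound carries this group. The nearest guide is compound 3, with a 1.8-fold higher number from compound 2 to compound 3 (0.24 log units; within the scatter). A wider guide is a 2.6-fold higher number from compound 1 to compound 3 (0.41 log units; beyond the scatter). A step of similar size and direction to the first guide is therefore expected, not clearly beyond the scatter. The estimated step is a 1.6-fold higher number from compound 2 to compound 4 (0.20 log units; within the scatter). For compound 4 the estimated value is 5.5 ug/mL, with an expected range from 2.8 ug/mL to 11 ug/mL.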

Compound 4, half-maximal inhibitory concentration: 2.61 ug/mL
Compound 4: middle estimate off by 2.1-fold (0.32 log units), on the high side; measured number below the stated range.
By their numbers in this assay, from the lowest: compounds 1, 4, 2 and 3 (each within the scatter of the next, the first and the last beyond it).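

In this assay, going by these compounds alone, the place of the ring nitrogen matters at this saturated ring carbon: pyridin-3-yl in place of pyridin-2-yl gives the only new step beyond the scatter (a 2.3-fold lower number from compound 3 to compound 4 (0.36 log units; beyond the scatter)). Pyridin-3-yl stays within the scatter of both halogenated phenyl groups (a 1.3-fold lower number from compound 2 to compound 4 (0.12 log units; within the scatter); a 1.1-fold higher number from compound 1 to compound 4 (0.04 log units; within the scatter)). A ring nitrogen therefore does not by itself set a compound apart from those with 2-fluorophenyl or 2-chlorophenyl here.

Going by these compounds, whether pyridin-4-yl or an aminophenyl group would fall with pyridin-3-yl or pyridin-2-yl remains open. Nothing available explains the gap between the two pyridinyl groups.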